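Trifluoromethyl for Chloro on a Shared Core

The compounds below may be only part of what the source reports. "The series", "measured", "known", "first", "only" and "open" are said of these compounds alone.

Compound 2 has the structure `Cc1c(O)ccc2c1[C@H](Cn1cc(-c3ccc(Cl)cc3)nn1)[C@@]13CC(=O)[C@@](C)(CC[C@@H]21)C3`. In a functional assay on SW480 cells (Homo sapiens) for cytotoxicity, read by MTT assay, with a stated time of 4 days (on this read-out higher numbers stand for weaker inhibition and lower numbers for stronger inhibition), compound 2 gives > 20000 nM, which is a limit of the assay rather than a number. Compound 1, `Cc1c(O)ccc2c1[C@H](Cn1cc(-c3ccccc3)nn1)[C@@]13CC(=O)[C@@](C)(CC[C@@H]21)C3`, has hydrogen in place of that chloro. In this assay compound 1 gives > 20000 nM, again a limit. Compound 3, `Cc1ccc(S(=O)(=O)Oc2ccc3c(c2C)[C@H](Cn2cc(-c4ccc(Cl)cc4)nn2)[C@@]24CC(=O)[C@@](C)(CC[C@@H]32)C4)cc1`, carries a (4-methylphenyl)sulfonyl group on the oxygen on the aromatic ring. In this assay compound 3 gives > 20000 nM, also a limit. The step from compound 1 to compound 2 reads a step that the two limits leave unreadable from compound 1 to compound 2, and the step from compound 2 to compound 3 reads a step that the two limits leave unreadable from compound 2 to compound 3. (the limit of > 20000 nM in this assay, at which 3 of the 3 values shown sit).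

Compound 4, `Cc1c(O)ccc2c1[C@H](Cn1cc(-c3ccc(C(F)(F)F)cc3)nn1)[C@@]13CC(=O)[C@@](C)(CC[C@@H]21)C3`, differs from compound 2 by trifluoromethyl in place of chloro on an aromatic carbon. Both measured steps around compound 2 leave no readable size, so they give no guide to the direction of this change; they show only that neither the chloro on the aromatic ring nor the sulfonyl on the oxygen brought the value into the measured range. Compound 4 is expected to sit at the limit as well, with an expected step that the limit leaves unreadable from compound 2 to compound 4. The estimate for compound 4 is 30000 nM, within a range from 12000 nM to 100000 nM.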

Compound 4, half-maximal inhibitory concentration: > 20000 nM
Compound 4: no number, only a limit (the forecaster's own chance of this, stated with the estimate: 85%); the middle value is on the limit's open side.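

In this assay compound 4 gives > 20000 nM and this is a limit, not a number. The steps to compound 4 from compound 1 and compound 2 therefore cannot be read: the limit of > 20000 nM in this assay, at which 4 of the 4 values shown sit. The compounds shown leave open how strongly any of them inhibits these cells, and whether hydrogen, chloro or trifluoromethyl on the aromatic ring makes any difference.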